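The source may report more compounds than this note shows. Statements on the series, on what has been measured and on what is new or still open speak of the compounds shown alone.

In a functional assay on PC-9 cells (Homo sapiens) for inhibition, read by MTT assay, with a stated time of 72 h (a lower number here means a stronger inhibitor, a higher number a weaker inhibitor), two compounds have been measured, compound 1 `C#CCSc1nc2nc(C)cc(Nc3cc(-c4ccccc4)[nH]n3)n2n1` and compound 2 `Cc1cc(Nc2cc(-c3ccccc3)[nH]n2)n2nc(SCc3ccc(C(F)(F)F)cc3)nc2n1`. Compound 1 gives > 50000 nM as its result, and this is a limit of the assay, not a number. Among the measured compounds shown here, compound 2 gives 4240 nM as the only actual number so far, so it stands alone. Compound 3 `CCCSc1nc2nc(C)cc(Nc3cc(-c4ccccc4)[nH]n3)n2n1` has yet to be measured. Its structure departs from compound 2 by ethyl in place of 4-(trifluoromethyl)phenyl on a saturated chain carbon bound to a sulfur in one place, with ethyl in place of 4-(trifluoromethyl)phenyl on a saturated chain carbon bound to a sulfur. For the measured compounds named here, one measured step bears on this change, the large one an at least 11-fold lower number from compound 1 to compound 2 (1.07 log units; beyond the scatter) that lies beyond the scatter and brought in 4-(trifluoromethyl)phenyl in place of ethynyl. The compound 1 end of that step rests on the limit of > 50000 nM in this assay, at which 1 of the 2 values shown sits, and is not a number. Compound 3 gives that group up again, so a large move to a higher number is expected in this assay rather than none. The expected step is a 7.1-fold higher number from compound 2 to compound 3 (0.85 log units; beyond the scatter) in size. For compound 3 the estimate is 30000 nM with an expected range from 10000 nM to 60000 nM in this measurement.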

Compound 3, half-maximal inhibitory concentration: > 50000 nM
Compound 3 was reported as a limit (the forecaster's own chance of this, stated with the estimate: 45%); middle value at least 1.6-fold (0.22 log units) away from the limit.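

In this assay, the change from 4-(trifluoromethyl)phenyl to ethyl on a saturated chain carbon bound to a sulfur gives an at least 11-fold higher number from compound 2 to compound 3 (1.07 log units; beyond the scatter), and the compound 3 end of that step is a limit of the assay, not a number. Earlier, only ethynyl had been set against 4-(trifluoromethyl)phenyl at this place; now a second small group, ethyl, also gives no actual number, so among the three compounds only the 4-(trifluoromethyl)benzyl group of compound 2 does, and none of them goes against this. The step from compound 1 to compound 3 cannot be read, and ethynyl and ethyl cannot be put in any order, as both compounds rest on one and the same limit: the limit of > 50000 nM in this assay, at which 2 of the 3 values shown sit.

The compounds shown leave open whether the number of compound 2 goes with the benzene ring alone or with its trifluoromethyl group, which a plain benzyl group at this place would begin to separate. They also leave open whether a longer chain without a ring, such as octyl, would give an actual number in this assay.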